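Swapping 4-fluorobenzyl for 3-bromobenzyl on a shared core

This account rests on a few compounds, and the source may have more. Where it says the series, first, only, none or still open, it means among the compounds named here.

Of the compounds shown here, three built on one shared core have been tested in a functional assay on K562 cells (Homo sapiens) for antiproliferative activity, with a stated time of 72 h; a lower number here means a stronger inhibitor, a higher number a weaker inhibitor. Compound 1 (`OC[C@H]1O[C@@H](n2cnc3c(NCc4ccccc4F)ncnc32)[C@H](O)[C@@H]1O`) gives 33200 nM, compound 3 (`OC[C@H]1O[C@@H](n2cnc3c(NCc4ccccc4Cl)ncnc32)[C@H](O)[C@@H]1O`) gives 64000 nM, and compound 2 (`OC[C@H]1O[C@@H](n2cnc3c(NCc4ccc(F)cc4)ncnc32)[C@H](O)[C@@H]1O`) gives 2700 nM. Compound 2 therefore has the lowest number of the three, making it the strongest inhibitor in this small set.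

Compound 4 (`OC[C@H]1O[C@@H](n2cnc3c(NCc4cccc(Br)c4)ncnc32)[C@H](O)[C@@H]1O`) has not been measured yet. It has 3-bromophenyl in place of 4-fluorophenyl on a saturated chain carbon bound to a nitrogen on an aromatic ring.

Within the data shown here, no measured step makes this exact swap, and no tested compound carries 3-bromophenyl. The closest evidence comes from two other changes at the same place, and both were large: a 12-fold lower number from compound 1 to compound 2 (1.09 log units; beyond the scatter) and a 24-fold higher number from compound 2 to compound 3 (1.37 log units; beyond the scatter). A third step, a 1.9-fold higher number from compound 1 to compound 3 (0.29 log units; within the scatter), stays within the scatter. The only measured replacement of the group in compound 2 raised the number, as a 24-fold higher number from compound 2 to compound 3 (1.37 log units; beyond the scatter) shows, so a rise is expected here too, though a smaller one and with real uncertainty. The expected step is a 3.3-fold higher number from compound 2 to compound 4 (0.52 log units; beyond the scatter). The estimate for compound 4 is 9000 nM, with an expected range from 2000 nM to 40000 nM.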

Compound 4, half-maximal inhibitory concentration: 19700 nM
Estimate against measurement, compound 4: 2.2-fold (0.34 log units) below, within the range that was stated.
By their numbers in this assay, from the lowest: compound 2; then compounds 4, 1 and 3 (each within the scatter of the next, the first and the last beyond it).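

In this assay, 3-bromophenyl is a third group at this position that falls well short of 4-fluorophenyl, with a 7.3-fold higher number from compound 2 to compound 4 (0.86 log units; beyond the scatter), so compound 2 now stands apart from all three other compounds by steps beyond the scatter. The other three are much closer to one another: a 1.7-fold lower number from compound 1 to compound 4 (0.23 log units; within the scatter) stays within the scatter, while a 3.2-fold lower number from compound 3 to compound 4 (0.51 log units; beyond the scatter) goes just beyond it, and this is a smaller step than any of those from compound 2. None of the data shown explain why 4-fluorophenyl stands apart from the other groups.

The four compounds change both the halogen and its place on the ring, so they cannot show whether the advantage of compound 2 comes from fluorine, from the 4-position, or from the two together; 4-bromobenzyl and 3-fluorobenzyl would separate those two changes directly. Plain benzyl, with no halogen at all, would show whether the halogens in compounds 1, 3 and 4 weaken the compounds or the fluorine in compound 2 strengthens it.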